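The source may report more compounds than this note shows. Statements on the series, on what has been measured and on what is new or still open speak of the compounds shown alone.

Measured compounds in a functional assay on MCF7 cells (Homo sapiens) for cytotoxicity, read by MTT assay, with a stated time of 24 h; a higher number here means a weaker inhibitor, a lower number a stronger inhibitor:
compound 1 `Cc1cc(-c2nc3cc(Cl)ccc3o2)ccc1NC(=O)CN1CCN(CCN(C)C)CC1` gives 39300 nM
compound 2 `Cc1cc(-c2nc3cc(F)ccc3o2)ccc1NC(=O)CCl` gives > 100000 nM, a limit of this assay and not a number
compound 3 `Cc1cc(-c2nc3ccccc3o2)ccc1NC(=O)CCl` gives 29800 nM

Compound 3 and compound 1 sit within the scatter of each other in this assay. Compound 2 returns only a limit. Going by the values given here, the one step with a number at its lower end is an at least 3.3-fold lower number from compound 2 to compound 3 (0.52 log units; beyond the scatter), a change on the fused ring of the shared core.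

Compound 4 `Cc1ccc2oc(-c3ccc(NC(=O)CCl)c(C)c3)nc2c1` differs from compound 3 by methyl in place of hydrogen on an aromatic carbon, on an aromatic carbon of a six-membered aromatic ring of carbon only, part of a fused or bridged system of two rings, meta to a fused ring and para to a fused ring. No measured pair shows methyl in place of hydrogen at any position, so the fluoro-to-hydrogen step is only a loose guide: a ring substituent on the fused ring moved the number beyond the scatter in the single case seen, but the direction for a methyl is not shown. The expectation for compound 4 is therefore a number near that of compound 3, with the step of a 1.0-fold higher number from compound 3 to compound 4 (0.00 log units; within the scatter) expected to stay within the scatter. Compound 4 is estimated at 30000 nM, between 10000 nM and 90000 nM.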

Compound 4, half-maximal inhibitory concentration: 96500 nM
Beside the measured number, compound 4's estimate is 3.2-fold (0.51 log units) below it; measured number outside the range, above it.
By their numbers in this assay, from the lowest: compounds 3 and 1 (each within the scatter of the next); then compound 4. At a limit, above all of these: compound 2.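

In this assay, going by these compounds alone, the methyl step gives the first direct reading for this group on an aromatic carbon of the six-membered aromatic ring of carbon only, part of a fused or bridged system of two rings: a 3.2-fold higher number from compound 3 to compound 4 (0.51 log units; beyond the scatter). Together with an at least 3.3-fold lower number from compound 2 to compound 3 (0.52 log units; beyond the scatter), this places hydrogen at the low end among compound 2, compound 3 and compound 4, with neither fluoro nor methyl matching it at this position and no compound among these three going against that reading. The remaining step reads an at least 1.0-fold lower number from compound 2 to compound 4 (0.01 log units; that floor lies within the scatter), which is only a floor, so methyl and fluoro at this position cannot be ordered against each other: the limit of > 100000 nM in this assay, at which 1 of the 4 values shown sits.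

Within the data shown here, still open is whether a methoxy group, an amine or a carboxylic acid at this position would follow the same direction, since the only groups compared here with hydrogen are methyl and fluoro. As far as these compounds go, it is also open whether the methyl step holds with the longer piperazine-bearing side chain of compound 1, as every step here rests on the chloroacetamide compounds.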